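Chain-lengthened thioamide analogue of compound 3: working notes

The compounds below may be only part of what the source reports. "The series", "measured", "known", "first", "only" and "open" are said of these compounds alone.

Measured compounds:
compound 1 `N=C(S)CCCn1nc(-c2ccccc2)ccc1=O`: 75.6%
compound 2 `C/N=C(\S)CCn1nc(-c2ccccc2)ccc1=O`: 68.2%
compound 3 `Cc1ccc(=O)n(CCCCCC(=N)S)n1`: 36.6%

Read-out: a functional assay on the whole organism (stomach) for inhibition, with Rattus norvegicus as the target, at a dose of 100 mg/kg by the intraduodenal route; on this read-out lower numbers stand for less inhibition and higher numbers for more inhibition at the one dose given (going by the name of the read-out).

Compound 3 stands lowest of the three numbers; compound 2 is nearest above it and compound 1 furthest, both gaps beyond the scatter.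

Compound 4 `Cc1ccc(=O)n(CCCCCCC(=N)S)n1` is not yet measured. Change from compound 3: a group of 4 heavy atoms (2 carbon, 1 nitrogen, 1 sulfur; no ring) in place of a group of 3 heavy atoms (1 carbon, 1 nitrogen, 1 sulfur; no ring), on a saturated chain carbon, five bonds along the chain from an aromatic nitrogen

Among the measured compounds shown here, only one measured step exists, a number 7.4 percentage points lower from compound 1 to compound 2 (within the scatter), and it concerns a different place and a different exchange, so no step bears directly on this chain extension. Nothing in the series shows what lengthening the chain by the counted atoms does, so the expectation is for no step beyond the scatter.

For compound 4 the estimate in this assay is 40%, range 20% to 60%. The step thereby expected is a number 3.4 percentage points higher from compound 3 to compound 4 (within the scatter).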

Compound 4, a percentage reported as inhibition, in the whole organism at one dose (the size of the read-out at that dose, not a potency): 29.5%
Beside the measured number, compound 4's estimate is 10.5 percentage points above it; low and high end bracket the measured number.
By their numbers in this assay, from the lowest: compounds 4 and 3 (each within the scatter of the next); then compounds 2 and 1 (each within the scatter of the next).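

In this assay the chain extension gives a number 7.1 percentage points lower from compound 3 to compound 4 (within the scatter). Among the compounds shown here, this is the first step read at this position, on a saturated chain carbon, five bonds along the chain from an aromatic nitrogen, and at the one dose given it leaves compound 3 and compound 4 indistinguishable. Nothing available explains this result.

From the compounds shown here alone, whether a longer chain or a carboxylic acid at this place would move the number beyond the scatter stays open. So does whether the same extension would behave alike on the core of compound 1.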